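Triazole series: methoxy to trifluoromethyl on the aryl ring

The source may report more compounds than this note shows. Statements on the series, on what has been measured and on what is new or still open speak of the compounds shown alone.

Measured compounds in a functional assay on A549 cells (Homo sapiens) for cytotoxicity, read by MTT assay, with a stated time of 4 days; a lower number here means a stronger inhibitor, a higher number a weaker inhibitor:
compound 1 `Cc1c(O)ccc2c1[C@H](Cn1cc(-c3ccccc3)nn1)[C@@]13CC(=O)[C@@](C)(CC[C@@H]21)C3`: > 20000 nM
compound 2 `C=C1C[C@]23C[C@@]1(O)CC[C@H]2c1cc(Br)c(O)c(C)c1[C@@H]3Cn1cc(-c2ccc(OC)cc2)nn1`: > 20000 nM

In this assay compound 1 reaches only a limit, > 20000 nM. Compound 2 likewise gives only a limit in this assay, > 20000 nM. Going by the values given here, both results sit at the same ceiling (the limit of > 20000 nM in this assay, at which 2 of the 2 values shown sit), so no step between measured compounds can be read and no direction is set for the series.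

Compound 3 `C=C1C[C@]23C[C@@]1(O)CC[C@H]2c1cc(Br)c(O)c(C)c1[C@@H]3Cn1cc(-c2ccc(C(F)(F)F)cc2)nn1` differs from compound 2 by trifluoromethyl in place of methoxy on an aromatic carbon. With nothing measured to lean on, the estimated step that the limit leaves unreadable from compound 2 to compound 3 is none beyond the scatter. Compound 3 is therefore expected at 30000 nM, within 10000 nM to 100000 nM, most probably reported again only as a limit.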

Compound 3, half-maximal inhibitory concentration: 9280 nM
Compound 3: middle estimate off by 3.2-fold (0.51 log units), on the high side; measured number below the stated range.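

In this assay compound 3 is the first compound shown to give a number instead of a limit, so the change from 4-methoxyphenyl to 4-(trifluoromethyl)phenyl can be read as a step (an at least 2.1-fold lower number from compound 2 to compound 3 (0.33 log units; beyond the scatter)). The group on this aromatic carbon, para to a large group, therefore moves the read-out on this core. The full size of the step remains unknown because its starting point is a limit: the limit of > 20000 nM in this assay, at which 2 of the 3 values shown sit.

Still open, from the compounds shown here alone, is whether an amine or a carboxylic acid at this position gives a lower number. Also open, going by these compounds, is whether trifluoromethyl has a similar effect on the core of compound 1.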